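Ethyl for Hydrogen on the Aminopyrimidine Nitrogen

This account rests on a few compounds, and the source may have more. Where it says the series, first, only, none or still open, it means among the compounds named here.

Measured so far:
- compound 1, `Nc1nccc(N2CC[C@H](NC(=O)Nc3ccc(Cl)c(C(F)(F)F)c3)C2)n1`: 30300 nM
- compound 2, `CNc1nccc(N2CC[C@H](NC(=O)Nc3ccc(OC(F)(F)F)cc3)C2)n1`: 70400 nM

Of the compounds shown here, two sharing a core have been measured in a physicochemical assay for solubility, measured as kinetic solubility; on this read-out higher numbers stand for higher solubility and lower numbers for lower solubility. Compound 1 gives 30300 nM, the lower of the two numbers. Compound 2 gives 70400 nM, and the gap between compound 2 and compound 1 lies beyond the usual scatter of this measurement. Compound 2 differs from compound 1 in more than one place, so no single change can be credited with that gap.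

Compound 3, `CCNc1nccc(N2CC[C@H](NC(=O)Nc3ccc(Cl)c(C(F)(F)F)c3)C2)n1`, is not yet measured. It differs from compound 1 in one place only:

ethyl in place of hydrogen on a nitrogen on an aromatic ring

For the measured compounds named here, no pair measured so far differs in exactly this way, so the effect of this change is not known from the data at hand. Going by the values given here, with no direct precedent, the most defensible expectation for the step in this assay is a modest one, perhaps a slight downward shift, not clearly beyond the scatter. The step from compound 1 to compound 3 is estimated as a 1.4-fold lower number from compound 1 to compound 3 (0.14 log units; within the scatter). Compound 3 is expected to give about 22000 nM, within a range from 8000 nM to 60000 nM.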

Compound 3, solubility: 29900 nM
Compound 3: the middle estimate sits 1.4-fold (0.13 log units) below what was measured; the measured number falls inside the stated range.
By their numbers in this assay, from the lowest: compounds 3 and 1 (each within the scatter of the next); then compound 2.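

In this assay the step from hydrogen to ethyl on a nitrogen on an aromatic ring reads a 1.0-fold lower number from compound 1 to compound 3 (0.01 log units; within the scatter) and lies within the scatter, so 2-aminopyrimidin-4-yl and 2-(ethylamino)pyrimidin-4-yl cannot be told apart on this read-out. For the compounds shown here, this is the first direct view of this position, showing that the ethyl group, with its 2 carbon atoms, can take the place of the hydrogen with no measurable shift in the number; compound 2 could not show this, as it differs from compound 1 in more than one place. No supporting measurement is available to explain this result.

Going by these compounds, it remains open whether a longer chain such as butyl, a ring such as cyclopropyl, or an ethyl chain ending in an amine or a carboxylic acid would also leave the number within the scatter of compound 1. Going by these compounds alone, it is also open whether the same ethyl step would read alike on a compound carrying the substituted phenyl group of compound 2 in place of the one in compound 1.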